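The source may hold more compounds than are shown below. What is called first, only, known or untested is meant among the compounds shown, and "the series" means these compounds.

Measured in a functional assay on the whole organism with Mus musculus as the target; on this read-out lower numbers stand for an effect already at smaller amounts and higher numbers for an effect only at larger amounts of compound:
- compound 1 `Cc1cc(N)c(C)c2c1OC(C)(C)C2`: 32.3 mg/kg
- compound 2 `Cc1c(N)cc2c(c1C)OC(C)(C)C2`: 24.4 mg/kg
- compound 3 `Cc1c(N)c(C)c2c(c1CN(C)C)OC(C)(C)C2`: > 50 mg/kg

Compound 3 gives no number, and its > 50 mg/kg is a limit of the assay. Compound 4 `Cc1c(N)c(C)c2c(c1CC(C)C)OC(C)(C)C2` differs from it by one change: isopropyl in place of dimethylamino on a saturated chain carbon bound to an aromatic carbon. In words, isopropyl stands in place of dimethylamino on a saturated chain carbon bound to an aromatic carbon. For the measured compounds named here, no measured pair isolates this change. Going by the values given here, the only guide is that compound 1 at 32.3 mg/kg and compound 2 at 24.4 mg/kg both give numbers in this assay, so a modest move towards smaller doses is expected, though with little certainty. The expected step is an at least 1.2-fold lower number from compound 3 to compound 4 (0.09 log units; that floor lies within the scatter). For compound 4 the estimate is 40 mg/kg, with an expected range from 15 mg/kg to 100 mg/kg.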

Compound 4, dose for 50% inhibition: 13.3 mg/kg
Compound 4: middle estimate off by 3.0-fold (0.48 log units), on the high side; measured number outside the range, below it.
By their numbers in this assay, from the lowest: compounds 4, 2 and 1 (each within the scatter of the next, the first and the last beyond it). At a limit, above all of these: compound 3.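

In this assay, isopropyl in place of dimethylamino on a saturated chain carbon bound to an aromatic carbon gives an at least 3.7-fold lower number from compound 3 to compound 4 (0.57 log units; beyond the scatter), so a group at this place can go with a measurable effect. Of the two compounds carrying a group there, only compound 4 gives a number, 13.3 mg/kg. The true size of the step stays unknown because compound 3 stands at a limit of the assay: the limit of > 50 mg/kg in this assay, at which 1 of the 4 values shown sits.

The compounds shown leave open how a longer chain, a primary amine or a carboxylic acid would read out at this place. They also leave open how far the step can be traced to the loss of the nitrogen alone.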